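This account rests on a few compounds, and the source may have more. Where it says the series, first, only, none or still open, it means among the compounds named here.

Measured so far in an ADME assay on Vero cells (Chlorocebus sabaeus) for cytotoxicity, read by MTT assay, with a stated time of 72 h; on this read-out lower numbers stand for stronger inhibition and higher numbers for weaker inhibition:
compound 1, `COc1cccc(-c2csc(NC(=O)c3ccco3)n2)c1`: > 90000 nM, which is a limit of the assay.
compound 2, `COc1cccc(-c2csc(NC(=O)c3ccc([N+](=O)[O-])o3)n2)c1`: 58700 nM.
compound 3, `COc1ccccc1-c1csc(NC(=O)c2ccc([N+](=O)[O-])o2)n1`: 42000 nM.

Compound 3 and compound 2 sit within the usual scatter of each other, as a 1.4-fold lower number from compound 2 to compound 3 (0.15 log units; within the scatter) shows, while compound 1 sits at the limit of > 90000 nM in this assay, at which 1 of the 3 values shown sits. Compound 4, `O=C(Nc1nc(-c2cccc(Br)c2)cs1)c1ccc([N+](=O)[O-])o1`, differs from compound 3 by 3-bromophenyl in place of 2-methoxyphenyl on an aromatic carbon. Going by the values given here, no measured step exchanges a methoxy group for bromine; the closest guide is the shift of the methoxy group, a 1.4-fold lower number from compound 2 to compound 3 (0.15 log units; within the scatter), which stayed within the scatter, and an at least 1.5-fold lower number from compound 1 to compound 2 (0.18 log units; that floor lies within the scatter) touches a different part of the molecule. In this assay no step beyond the scatter is therefore expected, and the estimate for compound 4 is 45000 nM, between 18000 nM and 90000 nM, meaning a 1.1-fold higher number from compound 3 to compound 4 (0.03 log units; within the scatter).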

Compound 4, half-maximal inhibitory concentration: 71000 nM
Compound 4: middle estimate off by 1.6-fold (0.20 log units), on the low side; measured number inside the range.
By their numbers in this assay, from the lowest: compounds 3, 2 and 4 (each within the scatter of the next). At a limit, above all of these: compound 1.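

Swapping methoxy for bromo on this phenyl ring does not move the result beyond the scatter (a 1.2-fold higher number from compound 2 to compound 4 (0.08 log units; within the scatter)). Going from 2-methoxyphenyl to 3-bromophenyl, which changes both the group and where it sits, also stays within the scatter (a 1.7-fold higher number from compound 3 to compound 4 (0.23 log units; within the scatter)). Nothing measured here explains these small steps.

The compounds shown leave open whether a phenyl ring carrying an amine or a carboxylic acid would give a step beyond the scatter. They also leave open how 2-bromophenyl would compare.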